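Maximal response notes on the shared-core series

A few compounds are considered here, and "the series" means these few. Any claim that something is new, unique, unknown or untested is made for them only; others in the source may bear on it.

For the measured compounds named here, compound 1 `CC(C)(C)OC(=O)N1CCC(O[C@H]2CC[C@H](Oc3ccc(S(C)(=O)=O)cc3F)CC2)CC1` and compound 2 `C[C@H](CF)OC(=O)N1CCC(O[C@H]2CC[C@H](Oc3cnc(S(C)(=O)=O)cn3)CC2)CC1` are the two measured members. In a functional assay on isolated protein for agonist activity at Glucose-dependent insulinotropic receptor (Homo sapiens), read by HTRF and cAMP accumulation (on this read-out higher numbers stand for larger maximal responses and lower numbers for smaller maximal responses), compound 1 gives 113%. In this assay compound 2 gives 108%, the lowest of the two numbers shown; its nearest neighbour is compound 1, with a gap that lies within the scatter, and since the two differ in more than one place no single-change step links them.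

Compound 3 `CS(=O)(=O)c1cnc(O[C@H]2CC[C@H](OC3CCN(C(=O)C4(C(F)(F)F)CC4)CC3)CC2)cn1` is still to be measured in this assay. Relative to compound 2 it carries a group of 7 heavy atoms (4 carbon, 3 fluorine; one three-membered non-aromatic ring of carbon only) in place of a group of 5 heavy atoms (3 carbon, 1 oxygen, 1 fluorine; no ring), on a carbonyl carbon. Going by the values given here, no measured step speaks to this kind of change. The expected step of a number 3 percentage points lower from compound 2 to compound 3 (within the scatter) is none beyond the scatter, because compound 2 gives 108% and compound 1 gives 113%, both close to the reference response. Compound 3 is estimated at 105%, with a range from 88% to 122%.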

Compound 3, largest response reached (Emax), in percent of the reference or control that the assay uses: 107%
Beside the measured number, compound 3's estimate is 2 percentage points below it, within the range that was stated.
By their numbers in this assay, from the lowest: compounds 3, 2 and 1 (each within the scatter of the next).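

In this assay, this gives the series its first single-place step: on a carbonyl carbon whose other neighbour is an amide-type nitrogen in a ring, 1-(trifluoromethyl)cyclopropyl enters in place of a group with no ring and 1 defined stereocentre, and the step reads a number 1 percentage points lower from compound 2 to compound 3 (within the scatter). At this position, the maximal response therefore holds across a change from a group with 1 hydrogen-bond acceptor to one with 0 hydrogen-bond acceptors. Nothing measured here bears on the reason for this outcome.

The compounds shown leave open whether a primary amine or a carboxylic acid on a longer chain at this carbonyl carbon would move the maximal response beyond the scatter. For the compounds shown here, they also leave open whether any group at this place can do so, as only one step has been read here.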